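The compounds below may be only part of what the source reports. "The series", "measured", "known", "first", "only" and "open" are said of these compounds alone.

Three compounds share one core and differ only in the aryl ring attached to the carbon that carries a double bond to nitrogen. Compound 1 `CC(c1ccc(-c2ccccc2)c(F)c1)c1nnc2n1N=C(c1ccc(Cl)cc1Cl)CS2` gives 6900 nM in a functional assay on HCT-116 cells (Homo sapiens) for inhibition, read by sulforhodamine B assay, with a stated time of 72 h (on this read-out higher numbers stand for weaker inhibition and lower numbers for stronger inhibition), compound 2 `CC(c1ccc(-c2ccccc2)c(F)c1)c1nnc2n1N=C(c1ccc(C(F)(F)F)cc1)CS2` gives 6100 nM, and compound 3 `CC(c1ccc(-c2ccccc2)c(F)c1)c1nnc2n1N=C(c1ccc(F)cc1)CS2` gives 10500 nM, the highest of the three numbers, although the steps of a 1.5-fold higher number from compound 1 to compound 3 (0.18 log units; within the scatter) and a 1.7-fold higher number from compound 2 to compound 3 (0.24 log units; within the scatter) both stay within the scatter, as does a 1.1-fold lower number from compound 1 to compound 2 (0.05 log units; within the scatter). Compound 4 `CC(c1ccc(-c2ccccc2)c(F)c1)c1nnc2n1N=C(c1ccc([N+](=O)[O-])cc1)CS2` differs from compound 3 by nitro in place of fluoro on an aromatic carbon. The closest comparison is a 1.7-fold higher number from compound 2 to compound 3 (0.24 log units; within the scatter), where one group in the same place was swapped for another and the number hardly moved, and the ring swaps involving compound 1 were just as small. Compound 4 is therefore expected to give 6500 nM in this assay, between 2500 nM and 15000 nM, a step of a 1.6-fold lower number from compound 3 to compound 4 (0.21 log units; within the scatter) that remains within the scatter.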

Compound 4, half-maximal inhibitory concentration: 7100 nM
Estimate against measurement, compound 4: 1.1-fold (0.04 log units) below, within the range that was stated.
By their numbers in this assay, from the lowest: compounds 2, 1, 4 and 3 (each within the scatter of the next).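

In this assay the 4-nitrophenyl ring stays within the scatter of all three earlier rings: the fluoro ring (a 1.5-fold lower number from compound 3 to compound 4 (0.17 log units; within the scatter)), the trifluoromethyl ring (a 1.2-fold higher number from compound 2 to compound 4 (0.07 log units; within the scatter)) and the 2,4-dichlorophenyl ring (a 1.0-fold higher number from compound 1 to compound 4 (0.01 log units; within the scatter)). Among the compounds shown here, the earlier rings carried only halogen-containing groups, so this is the first sign that a group without halogen, with more heavy atoms than fluoro and with hydrogen-bond acceptors, also gives a number within that scatter. No outside measurement is available to explain this result. From the compounds shown here alone, whether an amine or a carboxylic acid on this ring would give a number beyond the scatter remains open.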